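Series notes: removing the acetyl from compound 3

The source may hold more compounds than are shown below. What is called first, only, known or untested is meant among the compounds shown, and "the series" means these compounds.

Measured so far:
compound 1, `CC(C)c1onc(-c2c(Cl)cccc2Cl)c1COc1ccc(-c2nc3ccc(C(=O)O)cc3n2CC2CC2)cc1`, 19.4 nM
compound 2, `CC(C)c1onc(-c2c(Cl)cccc2Cl)c1COc1ccc(-c2nc3ccc(C(=O)O)cc3n2C2CCCC2)cc1`, 13.6 nM
compound 3, `CC(=O)C1CCC(Cn2c(-c3ccc(OCc4c(-c5c(Cl)cccc5Cl)noc4C(C)C)cc3)nc3ccc(C(=O)O)cc32)CC1`, 1170 nM

All three carry the same core and are read in an assay on Huh-7 cells for agonist activity at Bile acid receptor (Homo sapiens), read by a luciferase reporter; a higher number here means that more compound is needed for the effect, a lower number that less compound is needed. Compound 3 stands at the highest number of the three; compound 1 is nearest, compound 2 furthest, and both gaps lie beyond the scatter. The step from compound 1 to compound 3 is a 60-fold higher number from compound 1 to compound 3 (1.78 log units; beyond the scatter), and the step from compound 2 to compound 3 is an 86-fold higher number from compound 2 to compound 3 (1.93 log units; beyond the scatter), so the (4-acetylcyclohexyl)methyl group on the aromatic nitrogen goes with a large rise in the number, while the small change from cyclopropylmethyl to cyclopentyl, a 1.4-fold lower number from compound 1 to compound 2 (0.15 log units; within the scatter), stays within the scatter.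

Compound 4, `CC(C)c1onc(-c2c(Cl)cccc2Cl)c1COc1ccc(-c2nc3ccc(C(=O)O)cc3n2CC2CCCCC2)cc1`, is the next compound. It differs from compound 3 as follows: hydrogen in place of acetyl on a saturated ring carbon. The ring on the aromatic nitrogen is kept and only the acetyl on a saturated ring carbon is taken away, leaving a cyclohexylmethyl group.

Both large steps bear on this: the acetyl-bearing group is what set compound 3 apart from compound 1 and compound 2. Taking the acetyl away is therefore expected to bring the number down markedly, a step estimated as a 29-fold lower number from compound 3 to compound 4 (1.47 log units; beyond the scatter) in this assay, back toward the range of compound 1 and compound 2. Compound 4 is expected to give about 40 nM, within 10 nM to 200 nM.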

Compound 4, half-maximal effective concentration: 0.52 nM
Beside the measured number, compound 4's estimate is 77-fold (1.89 log units) above it; the measured number lies below the stated range.
By their numbers in this assay, from the lowest: compound 4; then compounds 2 and 1 (each within the scatter of the next); then compound 3.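

In this assay, among the compounds shown here, the earlier compounds could not separate the acetyl from the ring that bears it, as compound 3 alone carried both. Taking away only the acetyl gives a 2300-fold lower number from compound 3 to compound 4 (3.35 log units; beyond the scatter), so the high number of compound 3 goes with the acetyl on that saturated ring carbon and not with the cyclohexylmethyl group on the aromatic nitrogen. That group now also separates from the other two groups on this nitrogen, with a 26-fold lower number from compound 2 to compound 4 (1.42 log units; beyond the scatter) and a 37-fold lower number from compound 1 to compound 4 (1.57 log units; beyond the scatter), although cyclopropylmethyl and cyclopentyl had remained within the scatter of each other, and compound 4 has the lowest number of the four.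

As far as these compounds go, whether the rise belongs to the acetyl itself or would follow other groups on the same ring carbon stays open, and a hydroxyl, an amine or a carboxylic acid there would test this, as would a longer chain in place of the cyclohexylmethyl group on the aromatic nitrogen. No measurement available here speaks to the reason for either the loss with the acetyl or the gain with the cyclohexylmethyl group.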